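Moving a Methoxy Group on Two Related Amide Cores

A few compounds are considered here, and "the series" means these few. Any claim that something is new, unique, unknown or untested is made for them only; others in the source may bear on it.

Compound 1 `COc1ccc(-n2cc(NC(=O)c3cccc(NS(=O)(=O)c4ccccc4)c3)cn2)cc1` carries a 4-methoxyphenyl on an aromatic nitrogen. In a functional assay on MCF7 cells (Homo sapiens) for inhibition, read by MTT assay, with a stated time of 48 h (a higher number here means a weaker inhibitor, a lower number a stronger inhibitor), compound 1 gives 18700 nM. Compound 2 `COc1cccc(-n2cc(NC(=O)c3cccc(NS(=O)(=O)c4ccccc4)c3)cn2)c1` differs from it by a single change, (3-methoxyphenyl in place of 4-methoxyphenyl on an aromatic nitrogen), and in this assay compound 2 gives 16700 nM. The change produced a step of a 1.1-fold lower number from compound 1 to compound 2 (0.05 log units; within the scatter), so the two compounds are practically indistinguishable in this measurement.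

Compound 3 `COc1ccc(-n2cc(NC(=O)c3ccc(NS(=O)(=O)c4ccccc4)cc3)cn2)cc1` rests on a different core; the difference between the two cores is not broken down here. In this assay compound 3 gives 25600 nM. Set against the values of compound 1 and compound 2, the number for compound 3 lies within the scatter of both, so the three measured compounds show no clear separation from one another.

Compound 4 `COc1cccc(-n2cc(NC(=O)c3ccc(NS(=O)(=O)c4ccccc4)cc3)cn2)c1` has not yet been measured. It relates to compound 3 through (3-methoxyphenyl in place of 4-methoxyphenyl on an aromatic nitrogen), which is the same change that turned compound 1 into compound 2. Since that change on the core of compound 1 gave only a 1.1-fold lower number from compound 1 to compound 2 (0.05 log units; within the scatter), a step of similar, negligible size is expected on the core of compound 3 as well. The estimate for compound 4 in this assay is 23000 nM. This estimate means an expected step of a 1.1-fold lower number from compound 3 to compound 4 (0.05 log units; within the scatter). For compound 4 the expected range runs from 12000 nM to 46000 nM, with the actual value now awaited.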

Compound 4, half-maximal inhibitory concentration: 28400 nM
Estimate against measurement, compound 4: 1.2-fold (0.09 log units) below; low and high end bracket the measured number.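

In this assay, putting 3-methoxyphenyl in place of 4-methoxyphenyl on the core of compound 3 gave a 1.1-fold higher number from compound 3 to compound 4 (0.05 log units; within the scatter), so this pair of compounds cannot be told apart, just like the earlier pair on the other core. Placed side by side, the two steps agree, and on these two cores the swap carries over as a step too small to read: the same change on two cores in this assay, a 1.1-fold lower number (0.05 log units; within the scatter) from compound 1 to compound 2 and a 1.1-fold higher number (0.05 log units; within the scatter) from compound 3 to compound 4, 1.2-fold (0.09 log units) apart, within the scatter of two such steps. Among these compounds, this shows only that moving the methoxy group between these two named positions leaves the number within the scatter on both cores; it does not show that the swap would be equally silent on a third core, and it does not explain why the steps are so small, nor does it test whether a large effect would transfer, since neither step here rises above the scatter.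

The compounds shown leave open whether an amine or a carboxylic acid in place of the methoxy group, or a longer chain such as ethoxy or propoxy, would give a step beyond the scatter on either core. They also leave open whether these pairs would stay just as close in a different cell line or with a different exposure time.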